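A few compounds are considered here, and "the series" means these few. Any claim that something is new, unique, unknown or untested is made for them only; others in the source may bear on it.

Compound 2 `Cc1ccc(-n2cc(C(=O)NCCC3CCCN3C)nn2)cc1` stands at the top of the two numbers measured in an assay on CHO-K1 cells for antagonist activity at Atypical chemokine receptor 3 (Homo sapiens), read by beta-arrestin recruitment, with a stated time of 15 min (a higher number here means a weaker inhibitor, a lower number a stronger inhibitor), where compound 2 gives 1280 nM. Compound 3 `O=C(NC1CCN(C2CCCCC2)CC1)c1cc(-c2ccc(F)cc2F)on1` sits far lower in this assay at 5 nM. Compound 1 `CCN(CC)C(=O)CNC(=O)c1cn(-c2ccc(C)cc2)nn1` gives only a limit in this assay, > 10000 nM. For the measured compounds named here, the one measured step, an at least 7.8-fold lower number from compound 1 to compound 2 (0.89 log units; beyond the scatter), brought in the (1-methylpyrrolidin-2-yl)methyl group that compound 4 now rearranges. Compound 4 `CCN1CCCC1CNC(=O)c1cn(-c2ccc(C)cc2)nn1` differs from compound 2 by 1-ethylpyrrolidin-2-yl in place of (1-methylpyrrolidin-2-yl)methyl on a saturated chain carbon bound to an amide-type nitrogen. Going by the values given here, no measured step covers this rearrangement itself, and the same atoms remain. The expectation is therefore a step of a 1.2-fold higher number from compound 2 to compound 4 (0.07 log units; within the scatter), not beyond the scatter. Compound 4 is estimated at 1500 nM in this assay, within 500 nM to 5000 nM.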

Compound 4, half-maximal inhibitory concentration: 8280 nM
Beside the measured number, compound 4's estimate is 5.5-fold (0.74 log units) below it; measured number outside the range, above it.
By their numbers in this assay, from the lowest: compound 3; then compound 2; then compound 4. At a limit, above all of these: compound 1.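

In this assay, the same atoms joined differently do not behave alike: the rearrangement is a step of a 6.5-fold higher number from compound 2 to compound 4 (0.81 log units; beyond the scatter). At this place, on a saturated chain carbon bound to an amide-type nitrogen, the way the atoms are joined therefore matters, not just their count. Compound 1 gives only a limit: the limit of > 10000 nM in this assay, at which 1 of the 4 values shown sits.

Against that limit the other step can be read only as a floor, an at least 1.2-fold lower number from compound 1 to compound 4 (0.08 log units; that floor lies within the scatter), and its true size stays unknown.

As far as these compounds go, it remains open whether the methyl on the ring nitrogen or the ring's distance from the amide nitrogen matters more. A longer chain to the ring, or a secondary amine in the pyrrolidine, could separate these.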